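Alkenyl chain variation on the shared core: next step

The compounds below may be only part of what the source reports. "The series", "measured", "known", "first", "only" and "open" are said of these compounds alone.

Measured so far:
compound 1 `CC(C)=Cc1nc(C(F)(F)F)ccc1CNC(=O)C(C)c1ccc(NS(C)(=O)=O)c(F)c1`, 11.5 nM
compound 2 `CCC/C=C/c1nc(C(F)(F)F)ccc1CNC(=O)C(C)c1ccc(NS(C)(=O)=O)c(F)c1`, 0.9 nM

Among the compounds with values here, in an assay on CHO cells for antagonist activity at transient receptor potential cation channel subfamily V member 1 (Homo sapiens), read by FLIPR and calcium flux (on this read-out higher numbers stand for weaker inhibition and lower numbers for stronger inhibition), compound 2 stands lowest of the two numbers; its only neighbour is compound 1, and the step of a 13-fold lower number from compound 1 to compound 2 (1.11 log units; beyond the scatter) lies beyond the scatter. Compound 3 `CC(C(=O)NCc1ccc(C(F)(F)F)nc1/C=C/C1CCCCC1)c1ccc(NS(C)(=O)=O)c(F)c1` is not yet measured. It differs from compound 2 by cyclohexyl in place of propyl on a double-bonded chain carbon bound to a double-bonded chain carbon.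

Within the data shown here, one measured step bears on this part of the molecule, a 13-fold lower number from compound 1 to compound 2 (1.11 log units; beyond the scatter), which exchanged one alkenyl chain for another on an aromatic carbon and was large. Among the measured compounds shown here, that step does not show what a ring at the chain end does; the only guide is that the chain end has already moved the number strongly once. The expected step is a 1.7-fold higher number from compound 2 to compound 3 (0.22 log units; within the scatter), with the direction uncertain and most likely within the scatter, a moderately higher number not excluded. Compound 3 is expected at 1.5 nM in this assay, with a range from 0.4 nM to 6 nM.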

Compound 3, inhibition constant: 0.7 nM
Beside the measured number, compound 3's estimate is 2.1-fold (0.33 log units) above it; measured number inside the range.
By their numbers in this assay, from the lowest: compounds 3 and 2 (each within the scatter of the next); then compound 1.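

In this assay, cyclohexyl in place of propyl on a double-bonded chain carbon bound to a double-bonded chain carbon gives a 1.3-fold lower number from compound 2 to compound 3 (0.11 log units; within the scatter) and so stays within the scatter: at this position, a chain end carrying a non-aromatic ring of carbon only and an open propyl end cannot be told apart. Measured against compound 1, 2-cyclohexylethenyl in place of 2-methylprop-1-en-1-yl gives a 16-fold lower number from compound 1 to compound 3 (1.22 log units; beyond the scatter) and is large, as is a 13-fold lower number from compound 1 to compound 2 (1.11 log units; beyond the scatter) in the same comparison, so the large step away from compound 1 is not confined to an open chain. Nothing available accounts for either large step or for the lack of separation between compound 2 and compound 3.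

The compounds shown leave open whether an aromatic phenyl ring or a cyclohexyl ring bearing an amine or a hydroxyl would stay with compound 2 and compound 3 or move towards compound 1. They also leave open whether the double bond matters, as a saturated 2-cyclohexylethyl chain would show, and how a longer open chain would compare with pent-1-en-1-yl.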